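A Second Chloro Substituent and Its Expected Effect on Cytotoxicity

The compounds below may be only part of what the source reports. "The series", "measured", "known", "first", "only" and "open" are said of these compounds alone.

Measured so far in a functional assay on HepG2 cells (Homo sapiens) for cytotoxicity; a higher number here means a weaker inhibitor, a lower number a stronger inhibitor: compound 1, `Cc1ccc(S(=O)(=O)N/C(=N\O)Nc2ccc(Cl)cc2)cc1`, gives 49 ug/mL; compound 2, `Cc1c(S(=O)(=O)N/C(=N\O)Nc2ccc(Cl)cc2)sc2ccc(Cl)cc12`, gives 140 ug/mL; compound 3, `Cc1ccc(S(=O)(=O)N/C(=N\O)Nc2ccc(Cl)c(Cl)c2)cc1`, gives 72 ug/mL.

Compound 3 differs from compound 1 by chloro in place of hydrogen on an aromatic carbon. In this assay this change produced a 1.5-fold higher number from compound 1 to compound 3 (0.17 log units; within the scatter), a step that stays within the usual scatter of the measurement. Compound 2 carries a different core from compound 1; the difference between the two cores is not broken down here. Its number in this assay lies beyond the scatter from compound 1 but within the scatter from compound 3, so no order between compound 2 and compound 3 can be read from these values.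

Compound 4, `Cc1c(S(=O)(=O)N/C(=N\O)Nc2ccc(Cl)c(Cl)c2)sc2ccc(Cl)cc12`, has not yet been measured. It differs from compound 2 by chloro in place of hydrogen on an aromatic carbon, the same change that separates compound 3 from compound 1, made in the same place. Among the measured compounds shown here, because that change gave a 1.5-fold higher number from compound 1 to compound 3 (0.17 log units; within the scatter), the step from compound 2 to compound 4 in this assay is expected to be of similar size, a 1.4-fold higher number from compound 2 to compound 4 (0.15 log units; within the scatter), resting on the single measured pair alone. Compound 4 is therefore estimated to give about 200 ug/mL, most likely between 100 ug/mL and 400 ug/mL.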

Compound 4, half-maximal inhibitory concentration: > 300 ug/mL
Compound 4 gave a limit, no number; the forecaster's own chance of this, stated with the estimate: 20%; at least 1.5-fold (0.17 log units) between middle value and limit.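

In this assay compound 4 gave a limit of the assay and no number: the limit of > 300 ug/mL in this assay, at which 1 of the 4 values shown sits. Chloro in place of hydrogen on an aromatic carbon, turning 4-chlorophenyl into 3,4-dichlorophenyl, gave an at least 2.1-fold higher number from compound 2 to compound 4 (0.33 log units; beyond the scatter), a step beyond the scatter, whereas the same change on the core of compound 1 gave a 1.5-fold higher number from compound 1 to compound 3 (0.17 log units; within the scatter), a step within it. This shows that the change can produce a step beyond the scatter on one core and not on the other, but it does not show that the size of the step depends on the core: the same change on two cores in this assay, a 1.5-fold higher number (0.17 log units; within the scatter) from compound 1 to compound 3 and an at least 2.1-fold higher number (0.33 log units; beyond the scatter) from compound 2 to compound 4; the limit leaves it open whether they differ.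

The compounds shown leave open whether a bromo, methoxy or trifluoromethyl group entering in place of that hydrogen would give steps of similar size on both cores. They also leave open how far the true value of compound 4 lies past its limit, and whether the step on a third core would fall within or beyond the scatter.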